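Trimming the sulfonyl group from a chloroaryl to methyl

A few compounds are considered here, and "the series" means these few. Any claim that something is new, unique, unknown or untested is made for them only; others in the source may bear on it.

Compound 1 `O=S(=O)(Nc1ccc(-c2nc3ccccc3o2)cc1)c1cccc(F)c1`: 71000 nM
Compound 2 `O=S(=O)(Nc1ccc(-c2nc3ccccc3o2)cc1)c1cccc(Cl)c1`: 54000 nM

In an assay on cells for inhibition of HSP60/HSP10 (Homo sapiens), with a stated time of 60 min (a lower number here means a stronger inhibitor, a higher number a weaker inhibitor), compound 2 stands at 54000 nM and compound 1 at 71000 nM; the two numbers lie within the scatter of each other. Within the data shown here, the only measured step, a 1.3-fold lower number from compound 1 to compound 2 (0.12 log units; within the scatter), swaps one halogen for another and stays within the scatter. Compound 3 `CS(=O)(=O)Nc1ccc(-c2nc3ccccc3o2)cc1` goes further: methyl in place of 3-chlorophenyl on a sulfonyl sulfur. Among the measured compounds shown here, no measured step covers removing a whole aromatic ring from the sulfonyl sulfur, so the expectation rests on the size of the change alone. Compound 3 is expected to be a weaker inhibitor, estimated at 100000 nM with a range of 40000 nM to 250000 nM. That estimate means a step of a 1.9-fold higher number from compound 2 to compound 3 (0.27 log units; within the scatter).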

Compound 3, half-maximal inhibitory concentration: > 100000 nM
Compound 3 ended at the assay's limit; the forecaster's own chance of this, stated with the estimate: 30%; the middle value sits exactly at the limit.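

Compound 3, with methyl in place of the aromatic ring on the sulfonyl sulfur, gives no number, only a limit of this assay: the limit of > 100000 nM in this assay, at which 1 of the 3 values shown sits. Removing the whole ring therefore gives only floors, unlike the halogen swap, which gave a full step: an at least 1.8-fold higher number from compound 2 to compound 3 (0.26 log units; that floor lies within the scatter) and an at least 1.4-fold higher number from compound 1 to compound 3 (0.14 log units; that floor lies within the scatter). Both floors lie within the scatter, so the ring's removal cannot yet be said to change the result, although the true steps may be larger. On these data alone, whether a propyl chain or a benzyl group on the sulfonyl sulfur would give a readable number remains open.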